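Fluorophenoxy ketone series: step to pentafluorophenyl

The compounds below may be only part of what the source reports. "The series", "measured", "known", "first", "only" and "open" are said of these compounds alone.

Measured compounds in a functional assay on Jurkat cells (Homo sapiens); on this read-out higher numbers stand for weaker inhibition and lower numbers for stronger inhibition:
compound 1 `CC(C)[C@H](NC(=O)COc1cccc2ccccc12)C(=O)N[C@@H](CC(=O)O)C(=O)COc1ccccc1F`; compound 1 gives only an assay limit, > 100000 nM.
compound 2 `CC(C)[C@H](NC(=O)COc1cccc2ccccc12)C(=O)N[C@@H](CC(=O)O)C(=O)COc1cccc(F)c1`; compound 2 likewise gives only an assay limit, > 100000 nM.

Among the compounds with values here, compound 2 thus stands at the limit of > 100000 nM in this assay, at which 2 of the 2 values shown sit, and the one measured step, a step that the two limits leave unreadable from compound 1 to compound 2, cannot be read. Compound 3 `CC(C)[C@H](NC(=O)COc1cccc2ccccc12)C(=O)N[C@@H](CC(=O)O)C(=O)COc1c(F)c(F)c(F)c(F)c1F` differs from compound 2 by 2,3,4,5,6-pentafluorophenyl in place of 3-fluorophenyl on an oxygen on a saturated carbon. No readable measured step bears on this change, so no direction can be taken from the numbers. Compound 3 is expected to remain near the limit, as an estimate 100000 nM (range 30000 nM to 300000 nM). The step this estimate means, a number no higher from compound 2 to compound 3 (the limit leaves the size open), is expected to be none beyond the scatter.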

Compound 3, half-maximal inhibitory concentration: 3050 nM
For compound 3 the middle estimate is 33-fold (1.52 log units) above the measured one, and the stated range ends above it.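

Within the data shown here, at this position, on an oxygen on a saturated carbon, 2,3,4,5,6-pentafluorophenyl gives the only readable number so far in this assay (an at least 32-fold lower number from compound 2 to compound 3 (1.51 log units; beyond the scatter)) (an at least 32-fold lower number from compound 1 to compound 3 (1.51 log units; beyond the scatter)). The single-fluorine aryl groups of compound 1 and compound 2 stay at an assay limit, and the step between them cannot be read: the limit of > 100000 nM in this assay, at which 2 of the 3 values shown sit.

The compounds shown do not tell whether all five fluorines are needed or whether fewer would serve. From the compounds shown here alone, how a plain phenyl or a chlorine-bearing phenyl would read at this position remains open.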